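Oxime to Ketone on a Shared Triazole Thioether Core

The source may report more compounds than this note shows. Statements on the series, on what has been measured and on what is new or still open speak of the compounds shown alone.

Of the compounds shown here, two with a common triazole thioether core have been tested in a functional assay on the whole organism (strain albino) for inhibition, with Rattus norvegicus as the target, read by paw edema, with a stated time of 5 h, at a dose of 0.28 mmol/kg by the oral route; a lower number here means less inhibition, a higher number more inhibition at the dose given (going by the name of the read-out). Compound 1 `C=CCn1c(SCC(=O)c2ccccc2)nnc1-c1ccccc1` carries an allyl group on the ring nitrogen and a benzoyl group on the chain; in this assay compound 1 gives 66%. Compound 2 `O/N=C(/CSc1nnc(-c2ccccc2)n1-c1ccccc1)c1ccccc1` carries a phenyl group on the ring nitrogen and an oxime on the chain; in this assay compound 2 gives 75%. The two numbers lie within the usual scatter of each other, so neither compound can be set apart from the other.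

Compound 3 `O=C(CSc1nnc(-c2ccccc2)n1-c1ccccc1)c1ccccc1` keeps the phenyl group of compound 2 and differs from it in one place: a group of 8 heavy atoms (7 carbon, 1 oxygen; one six-membered aromatic ring of carbon only) in place of a group of 9 heavy atoms (7 carbon, 1 nitrogen, 1 oxygen; one six-membered aromatic ring of carbon only), on a saturated chain carbon bound to a sulfur.

Compound 1 already shows that a benzoyl group on this chain gives 66%, so the expected step from compound 2 to compound 3 is a number 7 percentage points lower from compound 2 to compound 3 (within the scatter), which stays within the scatter. Compound 3 is therefore expected to reach 68%, with a range from 55% to 80%.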

Compound 3, a percentage reported as inhibition, in the whole organism at one dose (the size of the read-out at that dose, not a potency): 63%
Compound 3: middle estimate off by 5 percentage points, on the high side; low and high end bracket the measured number.
By their numbers in this assay, from the lowest: compounds 3, 1 and 2 (each within the scatter of the next, the first and the last beyond it).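

On a saturated chain carbon bound to a sulfur, benzoyl in place of the oxime-bearing group gives a number 12 percentage points lower from compound 2 to compound 3 (beyond the scatter) in this assay, the first difference in this small set that stands clear of the usual scatter, though it is modest. With benzoyl kept on the chain, phenyl in place of allyl on an aromatic nitrogen gives a number 3 percentage points lower from compound 1 to compound 3 (within the scatter) and so cannot be told apart from repeat variation, which means this swap shows no clear effect on the read-out. Nothing in the data at hand explains why the oxime-bearing group and benzoyl differ.

Open, going by these compounds, is whether an amine or a carboxylic acid at this place on the chain would match the oxime-bearing group or fall to the level of benzoyl. Also open, on these data alone, is whether the same step appears with allyl on the ring nitrogen, or on a longer chain.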